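Swapping an Amide Arm for an Oxazole Ring

This account rests on a few compounds, and the source may have more. Where it says the series, first, only, none or still open, it means among the compounds named here.

Three compounds have been measured in a functional assay on MIA PaCa-2 cells (Homo sapiens) for inhibition, read by MTT assay, with a stated time of 7 days; on this read-out higher numbers stand for weaker inhibition and lower numbers for stronger inhibition:
Compound 1 `CCN(CC)S(=O)(=O)c1ccc(S(=O)(=O)N2CCC[C@@H](C(=O)N[C@@H]3CCN(C(=O)OC(C)(C)C)C3)C2)cc1` gives 200 nM.
Compound 2 `CCN(CC)S(=O)(=O)c1ccc(S(=O)(=O)N2CCC[C@@H](C(=O)N3CCN(c4nc(C)no4)CC3)C2)cc1` gives 250 nM.
Compound 3 `CCN(CC)S(=O)(=O)c1ccc(S(=O)(=O)N2CCC[C@@H](C(=O)NC3CN(S(C)(=O)=O)C3)C2)cc1` gives 2500 nM.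

Compound 3 has the highest number of the three, so it is the weakest inhibitor here. Going from compound 1 to compound 3 gives a 13-fold higher number from compound 1 to compound 3 (1.10 log units; beyond the scatter), and going from compound 2 to compound 3 gives a 10-fold higher number from compound 2 to compound 3 (1.00 log units; beyond the scatter). Both steps lie beyond the scatter, and both alter only the group attached to the carbonyl of the shared core.

Compound 4 `CCN(CC)S(=O)(=O)c1ccc(S(=O)(=O)N2CCC[C@@H](c3cc(C)no3)C2)cc1` removes that carbonyl altogether: 3-methyl-1,2-oxazol-5-yl in place of (1-(methylsulfonyl)azetidin-3-yl)carbamoyl on a saturated ring carbon. Within the data shown here, no measured step changes this part of the core in such a way, so the two known steps bear on it only loosely. They show that the group at this position can move the number a long way, and that compounds 1 and 2 sit far lower than compound 3. Compound 4 is therefore expected to fall somewhere between those extremes, with a 2.5-fold lower number from compound 3 to compound 4 (0.40 log units; beyond the scatter) as the expected step. The estimate for compound 4 in this assay is 1000 nM, within a range from 200 nM to 6000 nM.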

Compound 4, half-maximal inhibitory concentration: 4900 nM
Compound 4: the middle estimate sits 4.9-fold (0.69 log units) below what was measured; the measured number falls inside the stated range.
By their numbers in this assay, from the lowest: compounds 1 and 2 (each within the scatter of the next); then compounds 3 and 4 (each within the scatter of the next).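

In this assay, 3-methyl-1,2-oxazol-5-yl in place of (1-(methylsulfonyl)azetidin-3-yl)carbamoyl gives a 2.0-fold higher number from compound 3 to compound 4 (0.29 log units; within the scatter), so these two compounds cannot be told apart. At this position, then, a much smaller aromatic ring with no carbonyl and no hydrogen-bond donor leaves the number where compound 3 already had it, and this swap does not bring it down to the level of compounds 1 and 2. Nothing available explains this result.

Still open, on these data alone, is whether the carbonyl or the group beyond it matters more at this position. A 3-methyl-1,2-oxazol-5-yl ring attached through a carbonyl, or the same ring with an amine or a carboxylic acid in place of its methyl, would help to separate these possibilities.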